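The compounds below may be only part of what the source reports. "The series", "measured", "known", "first", "only" and "open" are said of these compounds alone.

In a toxicity assay on THP-1 cells (Homo sapiens) for inhibition (on this read-out lower numbers stand for higher toxicity in this test and higher numbers for lower toxicity in this test), compound 2 (`COc1ccc(-c2cnc(NC(=O)c3cccc(F)c3)n2C)cc1`) gives > 100000 nM and that is a limit, not a number. Compound 1 (`COc1ccc(-c2cnc(NC(=O)C3CCNCC3)n2C)cc1`) gives > 100000 nM and that too is a limit. Among the measured compounds shown here, the only measured step is a step that the two limits leave unreadable from compound 1 to compound 2 and it has no size that can be used. For the measured compounds named here, the sole guide is therefore the limit of > 100000 nM in this assay, at which 2 of the 2 values shown sit, and it shows neither piperidin-4-yl nor 3-fluorophenyl on the carbonyl carbon giving a number. Compound 3 (`COc1ccc(-c2cnc(NC(=O)C3CCOCC3)n2C)cc1`) carries oxan-4-yl in place of 3-fluorophenyl on a carbonyl carbon, a change counted as oxan-4-yl in place of 3-fluorophenyl on a carbonyl carbon in full. In this assay no change beyond the scatter is expected, so the estimated step is a number no higher from compound 2 to compound 3 (the limit leaves the size open) and the assay may again report only a limit. For compound 3 the estimated value is 100000 nM with an expected range from 50000 nM to 200000 nM in all.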

Compound 3, half-maximal cytotoxic concentration: > 100000 nM
Compound 3: only a limit was reported; the forecaster's own chance of this, stated with the estimate: 90%; the middle value sits exactly at the limit.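

In this assay compound 3 gives > 100000 nM, which is a limit and not a number. Among the compounds shown here, no step among compound 1, compound 2 and compound 3 can therefore be read. From the compounds shown here alone, whether piperidin-4-yl, 3-fluorophenyl and oxan-4-yl on the carbonyl carbon differ at all in toxicity stays open.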